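Dichlorophenyl series: methyl on the piperidine ring

The compounds below may be only part of what the source reports. "The series", "measured", "known", "first", "only" and "open" are said of these compounds alone.

Of the compounds shown here, two have been tested in an assay on isolated protein for inhibition of Maltase-glucoamylase (Homo sapiens), with stated times of 15 min and 10 min, tested at 64 uM; a lower number here means less inhibition, a higher number more inhibition at the concentration tested (going by the name of the read-out). Compound 1 `C=CCc1cc(-c2ccc(O)c(CC=C)c2)c(O)c(C(c2ccccc2)N2CCC(C)CC2)c1` gives 25.8% in this assay. Compound 2 `C=CCc1cc(-c2ccc(O)c(CC=C)c2)c(O)c(C(c2cc(Cl)cc(Cl)c2)N2CCCCC2)c1` gives 87.7% in this assay and stands highest of the two numbers; its distance to compound 1 lies beyond the scatter. Among the measured compounds shown here, these two compounds differ in more than one place, so no single-change step between measured compounds is available for guidance. Compound 3 `C=CCc1cc(-c2ccc(O)c(CC=C)c2)c(O)c(C(c2cc(Cl)cc(Cl)c2)N2CCC(C)CC2)c1` is the next compound to go into this assay. It differs from compound 2 by methyl in place of hydrogen on a saturated ring carbon. For the measured compounds named here, no measured pair shows what this change alone does; the step expected here is a number 7.7 percentage points lower from compound 2 to compound 3 (within the scatter), that is a small one, most likely none beyond the scatter, with a slight lean toward lower inhibition. Compound 3 is accordingly estimated at 80% in this assay, within a range from 55% to 95%.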

Compound 3, a percentage reported as inhibition, at one concentration (the size of the read-out at that concentration, not a potency): 97.5%
Compound 3: the middle estimate sits 17.5 percentage points below what was measured; measured number above the stated range.
By their numbers in this assay, from the lowest: compound 1; then compounds 2 and 3 (each within the scatter of the next).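

In this assay, 4-methylpiperidin-1-yl in place of piperidin-1-yl gives a number 9.8 percentage points higher from compound 2 to compound 3 (within the scatter), so with the 3,5-dichlorophenyl group present, methyl on this saturated ring carbon, three ring bonds from the ring nitrogen, brings no change beyond the scatter. Among the compounds shown here, with that methyl held constant, 3,5-dichlorophenyl in place of phenyl gives a number 71.7 percentage points higher from compound 1 to compound 3 (beyond the scatter), the first large step that can be tied to a single change. Nothing available explains the size of either step.

As far as these compounds go, whether an ethyl or a hydroxyl group on the same ring carbon would read like methyl remains open, as does whether a single chlorine on the phenyl ring would carry the large step. A reading at one concentration also leaves any difference in potency between compound 2 and compound 3 undefined.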